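Methyl to 4-Fluorophenyl on the Sulfonyl Sulfur

The compounds below may be only part of what the source reports. "The series", "measured", "known", "first", "only" and "open" are said of these compounds alone.

Compound 3 `CN(C)c1ccc(C2CC(c3ccc(-n4cncn4)cc3)=NN2S(C)(=O)=O)cc1` gives 10.8% in a functional assay on HCC1806 cells (Homo sapiens) for inhibition, read by sulforhodamine B assay, tested at 10 uM (on this read-out lower numbers stand for less inhibition and higher numbers for more inhibition at the one concentration tested (going by the name of the read-out)), the second highest of three numbers, within the scatter of both compound 1 `CC(=O)N1N=C(c2ccc(-n3cncn3)cc2)CC1c1ccc(N(C)C)cc1` at 11% and compound 2 `CN(C)c1ccc(C2CC(c3ccc(-n4cncn4)cc3)=NN2C(=O)c2cc(Cl)cc(Cl)c2)cc1` at 5.3%. Compound 4 `CN(C)c1ccc(C2CC(c3ccc(-n4cncn4)cc3)=NN2S(=O)(=O)c2ccc(F)cc2)cc1` differs from compound 3 by 4-fluorophenyl in place of methyl on a sulfonyl sulfur. The closest guide is a number 5.7 percentage points lower from compound 1 to compound 2 (within the scatter), where an aryl group also replaced methyl on the substituent carried by the ring nitrogen; likewise a number 0.2 percentage points lower from compound 1 to compound 3 (within the scatter) and a number 5.5 percentage points higher from compound 2 to compound 3 (within the scatter) stayed within the scatter. Any change for compound 4 is therefore expected to be small, a number 1.8 percentage points lower from compound 3 to compound 4 (within the scatter), and compound 4 is estimated at 9%, between 0% and 22%.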

Compound 4, a percentage reported as inhibition, at one concentration (the size of the read-out at that concentration, not a potency): 24.1%
Beside the measured number, compound 4's estimate is 15.1 percentage points below it; measured number above the stated range.
By their numbers in this assay, from the lowest: compounds 2, 3 and 1 (each within the scatter of the next); then compound 4.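

In this assay, going by these compounds alone, 4-fluorophenyl on the sulfonyl sulfur gives the first change at this position to pass beyond the scatter (a number 13.3 percentage points higher from compound 3 to compound 4 (beyond the scatter)), while all earlier changes stayed within it. The gain also holds against both carbonyl compounds (a number 18.8 percentage points higher from compound 2 to compound 4 (beyond the scatter); a number 13.1 percentage points higher from compound 1 to compound 4 (beyond the scatter)), so an aryl group does not behave alike on a sulfonyl sulfur and on a carbonyl carbon. Nothing measured here explains the rise. The compounds shown leave open whether the fluorine or the aromatic ring carries this step. They also leave open what unsubstituted phenyl, 4-methoxyphenyl or a small amine would give on the sulfonyl sulfur.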